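Working notes: cyano in place of 3-fluorophenyl

A few compounds are considered here, and "the series" means these few. Any claim that something is new, unique, unknown or untested is made for them only; others in the source may bear on it.

Going by the values given here, compound 1 `Cc1n[nH]c(C(=O)O)c1Cc1cccc(-c2cccc(F)c2)c1` gives 500 nM in an assay on isolated protein for inhibition of 2-Hydroxyacid oxidase 2 (Rattus norvegicus) (a lower number here means a stronger inhibitor, a higher number a weaker inhibitor), the lowest of the two numbers measured so far; compound 2 `Cc1n[nH]c(C(=O)O)c1Cc1ccc(-c2ccc(C(F)(F)F)cc2)cc1` gives 1100 nM in this assay, a gap beyond the usual scatter. Compound 3 `Cc1n[nH]c(C(=O)O)c1Cc1cccc(C#N)c1` differs from compound 1 by cyano in place of 3-fluorophenyl on an aromatic carbon. Among the compounds with values here, no measured pair isolates this change, so its effect in this assay is not known from the series. Both measured compounds carry the group that compound 3 loses; a weakening step is expected. The step from compound 1 to compound 3 is estimated at a 6.0-fold higher number from compound 1 to compound 3 (0.78 log units; beyond the scatter). Compound 3 is expected to give about 3000 nM, within a range of 800 nM to 12000 nM.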

Compound 3, half-maximal inhibitory concentration: 500 nM
For compound 3 the middle estimate is 6.0-fold (0.78 log units) above the measured one; the whole stated range lies above it.
By their numbers in this assay, from the lowest: compounds 1 and 3 (each within the scatter of the next); then compound 2.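

Cyano in place of 3-fluorophenyl gives no change at the digits printed from compound 1 to compound 3 (within the scatter) in this assay. Both earlier compounds carry a second aromatic ring, so they could not show that a value at the level of compound 1 persists without that ring at this position. The data at hand give no reason for this equivalence.
On these data alone, whether an amine, a carboxylic acid or plain hydrogen on this aromatic carbon would hold the same level stays open. Also open, as far as these compounds go, is whether cyano would behave alike on another carbon of the same ring.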